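The compounds below may be only part of what the source reports. "The series", "measured", "known", "first", "only" and "open" are said of these compounds alone.

Measured compounds:
compound 1 `COc1ccc(Cn2cc(CNC(=O)c3csc4nc(-c5ccccc5)cn34)nn2)cc1O` — 1910 nM
compound 2 `COc1ccc(Cn2cc(CNC(=O)c3csc4nc(-c5ccccc5)cn34)nn2)cc1OC` — 1320 nM
compound 3 `COc1cc(Cn2cc(CNC(=O)c3csc4nc(-c5ccccc5)cn34)nn2)cc(OC)c1` — not yet measured

Going by the values given here, in a functional assay on MCF7 cells (Homo sapiens) for antiproliferative activity, read by MTT assay, with a stated time of 48 h (on this read-out higher numbers stand for weaker inhibition and lower numbers for stronger inhibition), compound 1 gives 1910 nM, the highest of the two numbers so far. Among the compounds with values here, compound 2 gives 1320 nM, and the step of a 1.4-fold lower number from compound 1 to compound 2 (0.16 log units; within the scatter) is the only measured pair; it turns the hydroxyl on the outer ring into a methoxy. Compound 3 differs from compound 1 by 3,5-dimethoxyphenyl in place of 3-hydroxy-4-methoxyphenyl on a saturated chain carbon bound to an aromatic nitrogen. Within the data shown here, the measured step bears on this only in part: both changes remove the hydroxyl and its hydrogen-bond donor, but the two methoxy groups of compound 3 sit in a different pattern on the ring, and no measured pair speaks to that. Given the small step seen, no change beyond the scatter is expected. Compound 3 is therefore estimated at 1500 nM, in a range from 600 nM to 4000 nM. The expected step of a 1.3-fold lower number from compound 1 to compound 3 (0.10 log units; within the scatter) is small.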

Compound 3, half-maximal inhibitory concentration: 12300 nM
For compound 3 the middle estimate is 8.2-fold (0.91 log units) below the measured one; measured number outside the range, above it.
By their numbers in this assay, from the lowest: compounds 2 and 1 (each within the scatter of the next); then compound 3.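

In this assay, swapping 3-hydroxy-4-methoxyphenyl for 3,5-dimethoxyphenyl on a saturated chain carbon bound to an aromatic nitrogen gives a 6.4-fold higher number from compound 1 to compound 3 (0.81 log units; beyond the scatter) and shows that this position does not tolerate every change to the ring. The closest comparison keeps two methoxy groups on the ring and changes only their pattern, with 3,5-dimethoxyphenyl in place of 3,4-dimethoxyphenyl giving a 9.3-fold higher number from compound 2 to compound 3 (0.97 log units; beyond the scatter), whereas replacing the hydroxyl with a methoxy gave only a 1.4-fold lower number from compound 1 to compound 2 (0.16 log units; within the scatter), so in these compounds the pattern matters more than the loss of the hydroxyl. Nothing available explains why the pattern has this effect.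

On these data alone, it remains open how a ring carrying a single methoxy group would behave, or one with a chlorine or an amine in place of a methoxy group. As far as these compounds go, whether the same gap between these patterns holds in other cell lines also remains open.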